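This account rests on a few compounds, and the source may have more. Where it says the series, first, only, none or still open, it means among the compounds named here.

Of the compounds shown here, two have so far been measured in a functional assay on HL-60 cells (Homo sapiens) for antiproliferative activity, with a stated time of 24 h; on this read-out higher numbers stand for weaker inhibition and lower numbers for stronger inhibition. Compound 1 `Cc1ccc(C(=O)Nc2sc3c(c2C(N)=O)CCN(Cc2ccc(Cl)cc2Cl)C3)cc1` gives 19900 nM in this assay, and compound 2 `NC(=O)c1c(NC(=O)c2ccccc2)sc2c1CCN(C(=S)Nc1ccccc1Cl)C2` gives 13800 nM in this assay. These two numbers lie within the scatter of each other, so compound 2 stands alongside compound 1 rather than apart from it. Among the compounds with values here, the two compounds differ from one another in more than one place, so no single step between them is counted, and only their two values can be set side by side.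

The step followed here leads from compound 2 to compound 3 `NC(=O)c1c(NC(=O)c2ccncn2)sc2c1CCN(C(=S)Nc1ccccc1Cl)C2`, which has not yet been measured. The change is pyrimidin-4-yl in place of phenyl on a carbonyl carbon. Within the data shown here, nothing among the measured compounds shows this change, so no measured step gives a direction for it. The expectation is therefore that a 1.0-fold higher number from compound 2 to compound 3 (0.01 log units; within the scatter) will be no larger than the scatter, in either direction. On that basis compound 3 is estimated at 14000 nM in this assay, with a range from 4000 nM to 50000 nM.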

Compound 3, half-maximal inhibitory concentration: 34600 nM
Compound 3: middle estimate off by 2.5-fold (0.39 log units), on the low side; the range from low to high includes it.
By their numbers in this assay, from the lowest: compounds 2, 1 and 3 (each within the scatter of the next, the first and the last beyond it).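

Within the data shown here, the earlier compounds offered no measured step, so this is the first reading of any change at this position. In this assay, pyrimidin-4-yl in place of phenyl on a carbonyl carbon gives a 2.5-fold higher number from compound 2 to compound 3 (0.40 log units; beyond the scatter) and so moves the read-out toward weaker inhibition, a modest but real shift showing that the ring on this carbonyl is not a silent place in this pair, even though the number of heavy atoms stays the same and the ring remains six-membered and aromatic. No information at hand bears on what lies behind this shift.

The compounds shown leave open whether a ring with one nitrogen, such as pyridin-2-yl, pyridin-3-yl or pyridin-4-yl, would move the number as well, and whether it would do so to the same extent as pyrimidin-4-yl. They also leave open whether a saturated ring such as morpholin-4-yl or piperidin-1-yl would be tolerated on this carbonyl carbon, and whether phenyl bearing a methoxy group or a fluorine would take the read-out toward stronger inhibition.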